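From 2,4-Dichlorophenyl to 2,4-Difluorophenyl

The compounds below may be only part of what the source reports. "The series", "measured", "known", "first", "only" and "open" are said of these compounds alone.

Of the compounds shown here, three with a shared core have been tested in a functional assay on RT-112 cells (Homo sapiens) for antiproliferative activity, read by MTT assay, with a stated time of 72 h; on this read-out higher numbers stand for weaker inhibition of growth and lower numbers for stronger inhibition of growth. Compound 1 `COc1cc(Nc2ncnc3c(NC(=O)Nc4cc(Cl)cc(Cl)c4)cccc23)cc(OC)c1`, which carries a 3,5-dichlorophenyl group, gives 30.2 nM and is the most potent of the three. Compound 2 `COc1cc(Nc2ncnc3c(NC(=O)Nc4cccc(C)c4C)cccc23)cc(OC)c1`, with 2,3-dimethylphenyl, gives 5910 nM, and compound 3 `COc1cc(Nc2ncnc3c(NC(=O)Nc4ccc(Cl)cc4Cl)cccc23)cc(OC)c1`, with 2,4-dichlorophenyl, gives 3060 nM. Compound 3 therefore stands level with compound 2 and far from compound 1. The two large steps are a 200-fold higher number from compound 1 to compound 2 (2.29 log units; beyond the scatter) and a 100-fold higher number from compound 1 to compound 3 (2.01 log units; beyond the scatter), and both leave the 3,5-dichlorophenyl group behind. The remaining step, a 1.9-fold lower number from compound 2 to compound 3 (0.29 log units; within the scatter), lies within the scatter.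

Compound 4 `COc1cc(Nc2ncnc3c(NC(=O)Nc4ccc(F)cc4F)cccc23)cc(OC)c1` has 2,4-difluorophenyl in place of 2,4-dichlorophenyl on an amide-type nitrogen. Going by the values given here, no measured step exchanges chlorine for fluorine, so the evidence is indirect. The closest guide is the swap that gave a 1.9-fold lower number from compound 2 to compound 3 (0.29 log units; within the scatter), since compound 4 also leaves the 3,5-dichlorophenyl group absent. No step beyond the scatter is therefore expected in this assay, in either direction. The expected size of the change is a 1.1-fold higher number from compound 3 to compound 4 (0.06 log units; within the scatter). Compound 4 is estimated at about 3500 nM, with an expected range of 1000 nM to 12000 nM.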

Compound 4, concentration for 50% growth inhibition: 2460 nM
Compound 4: the middle estimate sits 1.4-fold (0.15 log units) above what was measured; the measured number falls inside the stated range.
By their numbers in this assay, from the lowest: compound 1; then compounds 4, 3 and 2 (each within the scatter of the next, the first and the last beyond it).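

In this assay, going by these compounds alone, replacing the 2,4-dichlorophenyl group with 2,4-difluorophenyl on the amide-type nitrogen gives a 1.2-fold lower number from compound 3 to compound 4 (0.09 log units; within the scatter), so this exchange of chlorine for fluorine, which no earlier pair tested, leaves the read-out unresolved at this place. Measured against the 2,3-dimethylphenyl group, the new group gives a 2.4-fold lower number from compound 2 to compound 4 (0.38 log units; beyond the scatter), a modest step where the chlorine-bearing compound 3 stayed within the scatter, though this small difference should not be overread. Measured against the 3,5-dichlorophenyl group, the change is an 81-fold higher number from compound 1 to compound 4 (1.91 log units; beyond the scatter), so the large gap seen with the 2,4-dichlorophenyl group also remains with the 2,4-difluorophenyl group, and no available measurement explains why these groups differ as they do.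

The compounds shown leave open whether a 3,5-difluorophenyl group would stay close to compound 1 at 30.2 nM or fall back towards the other three, which would show whether the chlorine atoms themselves matter in that arrangement. They also leave open how an unsubstituted phenyl group or a 3,5-dimethylphenyl group would read at this same place on the shared core.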